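Swapping a pyridine for a benzene on the amide nitrogen

The source may report more compounds than this note shows. Statements on the series, on what has been measured and on what is new or still open speak of the compounds shown alone.

Measured compounds:
compound 1, `O=C(Cn1c(=O)oc2cc([N+](=O)[O-])ccc21)Nc1ccccn1`: 38.6%
compound 2, `O=C(Cn1c(=O)oc2cc(Cl)ccc21)Nc1nc2ccccc2s1`: 38.7%
compound 3, `O=C(Cn1c(=O)oc2ccccc21)NCc1ccccn1`: 37.3%

Three compounds built on a shared core were tested in an ADME assay on RAW264.7 cells (Mus musculus) for cytotoxicity, read by MTT assay, with a stated time of 72 h, tested at 50 uM; on this read-out lower numbers stand for a weaker effect and higher numbers for a stronger effect at the one concentration tested. Compound 1 gives 38.6%. Compound 2 gives 38.7%, and compound 3 gives 37.3%. The three numbers lie within the usual scatter of one another, so on these figures compound 1 cannot be set apart from compound 2 or compound 3. Among the compounds with values here, no two of them differ in only one place, so no single step between measured compounds can be drawn.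

The next compound, compound 4, `O=C(Cn1c(=O)oc2cc([N+](=O)[O-])ccc21)Nc1ccccc1`, has not yet been measured in this assay. Relative to compound 1 its change is phenyl in place of pyridin-2-yl on an amide-type nitrogen. The measured compounds differ from one another in several places, including the group on the amide-type nitrogen, and their numbers still fail to separate. For that reason the step of a number 0.6 percentage points lower from compound 1 to compound 4 (within the scatter) is expected to be none beyond the scatter, because compound 2 gives 38.7% and compound 3 gives 37.3% with such different groups there. Compound 4 is therefore estimated to give about 38%, in a range from 28% to 48%.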

Compound 4, a percentage reported as inhibition, at one concentration (the size of the read-out at that concentration, not a potency): 18%
Beside the measured number, compound 4's estimate is 20 percentage points above it; measured number below the stated range.
By their numbers in this assay, from the lowest: compound 4; then compounds 3, 1 and 2 (each within the scatter of the next).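

Placing phenyl where pyridin-2-yl stood on the amide-type nitrogen gives a number 20.6 percentage points lower from compound 1 to compound 4 (beyond the scatter) in this assay. The earlier compounds shown here differ from one another in several places, so they could not isolate this group; this pair keeps the core of compound 1 unchanged and shows that the cytotoxicity read-out can respond to this one exchange, in which a ring nitrogen with its hydrogen-bond acceptor gives way to a ring of carbon only. Nothing measured here explains why the number drops.

This single pair cannot show whether the same exchange would have a similar effect on a core carrying a different substituent, such as those of compound 2 or compound 3, which also differ from compound 1 elsewhere. It also leaves open what would happen to the number if an amine or a carboxylic acid were carried on the phenyl ring of compound 4, or if a morpholine ring stood on the amide-type nitrogen in its place.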